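The source may hold more compounds than are shown below. What is called first, only, known or untested is meant among the compounds shown, and "the series" means these compounds.

Measured compounds:
compound 1 `COc1ncnc2c1c(-c1ccsc1)cn2[C@@H]1O[C@H](CO)[C@@H](O)[C@H]1O` — 430 nM
compound 2 `CN(C)c1ncnc2c1c(-c1ccsc1)cn2[C@@H]1O[C@H](CO)[C@@H](O)[C@H]1O` — a limit, > 20000 nM
compound 3 `CN(C)c1ncnc2c1c(-c1cc3ccccc3o1)cn2[C@@H]1O[C@H](CO)[C@@H](O)[C@H]1O` — a limit, > 20000 nM

The three compounds were tested in a functional assay on HepG2 cells (Homo sapiens) for antiproliferative activity, read by XTT assay, with a stated time of 72 h; a lower number here means a stronger inhibitor, a higher number a weaker inhibitor. Compound 1 gives 430 nM in this assay. For compound 2 the result is a limit and not a number, > 20000 nM. For compound 3 the result is also a limit, > 20000 nM.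

Between compound 2 and compound 1 the change is methoxy in place of dimethylamino on an aromatic carbon, and it makes a step of an at least 46-fold lower number from compound 2 to compound 1 (1.66 log units; beyond the scatter). The cores of compound 2 and compound 3 differ by 1-benzofuran-2-yl in place of thiophen-3-yl on an aromatic carbon, and the step there is a step that the two limits leave unreadable from compound 2 to compound 3 because of the limit of > 20000 nM in this assay, at which 2 of the 3 values shown sit.

Compound 4 `COc1ncnc2c1c(-c1cc3ccccc3o1)cn2[C@@H]1O[C@H](CO)[C@@H](O)[C@H]1O` is not yet measured. It differs from compound 3 by methoxy in place of dimethylamino on an aromatic carbon, the same change as from compound 2 to compound 1, at a place described in the same words. Since the result for compound 3 is a limit, the step to compound 4 is expected, not known. Compound 4 is expected to take a step of an at least 13-fold lower number from compound 3 to compound 4 (1.12 log units; beyond the scatter) in this assay, resting on the step of an at least 46-fold lower number from compound 2 to compound 1 (1.66 log units; beyond the scatter) seen for the same change. The estimate for compound 4 in this assay is 1500 nM, with a range from 250 nM to 20000 nM, and the measurement will show where it falls.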

Compound 4, half-maximal inhibitory concentration: > 20000 nM
Compound 4 gave a limit, no number; the forecaster's own chance of this, stated with the estimate: 30%; middle value at least 13-fold (1.12 log units) from the limit.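

In this assay the result for compound 4 is a limit and not a number, > 20000 nM, so the change from dimethylamino to methoxy, which gave an at least 46-fold lower number from compound 2 to compound 1 (1.66 log units; beyond the scatter) on the core carrying thiophen-3-yl, produces no measurable value on the core carrying 1-benzofuran-2-yl, and the step between compound 3 and compound 4, like the other steps between two limits, cannot be read because both ends rest on the same limit: the limit of > 20000 nM in this assay, at which 3 of the 4 values shown sit. With methoxy present in both compounds, 1-benzofuran-2-yl in place of thiophen-3-yl makes an at least 46-fold higher number from compound 1 to compound 4 (1.66 log units; beyond the scatter), so the gain seen with methoxy depends here on which group the core carries. This does not show that methoxy has no effect on the core of compound 3, since any difference between compound 3 and compound 4 would lie beyond the limit, and a single readable pair sets no rule for the series.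

Going by these compounds, it remains open how the change from dimethylamino to methoxy would behave with other groups in place of thiophen-3-yl, such as phenyl. On these data alone, it is equally open whether an amine with a single methyl group, or ethoxy, in place of methoxy would keep a measurable value on the core of compound 1.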